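Morpholin-4-yl to Thiomorpholin-4-yl on a Thiocarbonyl Carbon

The compounds below may be only part of what the source reports. "The series", "measured", "known", "first", "only" and "open" are said of these compounds alone.

In a functional assay on A-375 cells (Homo sapiens) for cytotoxicity, read by MTT assay, with a stated time of 72 h, tested at 3 uM (a lower number here means less inhibition of growth, a higher number more inhibition of growth at the concentration tested), compound 1 `N/C(=N\NC(=S)N1CCOCC1)c1ccccn1` gives 19.3%, while compound 2 `Cc1ccnc(/C(N)=N/NC(=S)N2CCOCC2)c1` gives 66.6%. Among the measured compounds shown here, the one measured step, a number 47.3 percentage points higher from compound 1 to compound 2 (beyond the scatter), sets compound 2 at the highest of the two numbers, with compound 1 as its only neighbour and the gap between them beyond the scatter.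

Compound 3 `Cc1ccnc(/C(N)=N/NC(=S)N2CCSCC2)c1` differs from compound 2 by thiomorpholin-4-yl in place of morpholin-4-yl on a thiocarbonyl carbon. For the measured compounds named here, no measured step bears on this change: the single measured step concerns a methyl group on an aromatic carbon, not the ring attached to the thiocarbonyl carbon. There is therefore nothing in the measured pairs to scale an effect of this exchange, and the plain expectation is a step of no size beyond the scatter in this assay. For compound 3 the expected step is a number 1.6 percentage points lower from compound 2 to compound 3 (within the scatter). For compound 3 the estimate in this assay is 65%, with a range from 45% to 85%. Going by the values given here, the range is kept wide; only two compounds have been measured, and neither tests the group on the thiocarbonyl carbon.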

Compound 3, percent growth inhibition at one concentration: 67.2%
Beside the measured number, compound 3's estimate is 2.2 percentage points below it; the measured number falls inside the stated range.
By their numbers in this assay, from the lowest: compound 1; then compounds 2 and 3 (each within the scatter of the next).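

In this assay, thiomorpholin-4-yl in place of morpholin-4-yl on a thiocarbonyl carbon comes to a number 0.6 percentage points higher from compound 2 to compound 3 (within the scatter), so this exchange of oxygen for sulfur in the six-membered ring leaves no difference that the read-out can resolve. Among the compounds shown here, the earlier pair spoke only to a methyl group on an aromatic carbon; this step is the first reading of the group on the thiocarbonyl carbon, and it shows that, on the core of compound 2, the two rings cannot be told apart at the single concentration tested. Nothing available explains why the two rings read alike.

The compounds shown leave open whether thiomorpholin-4-yl would read the same on the core of compound 1, which lacks the methyl group and gives a much lower number. They also leave open whether this position would accept a ring with carbon or nitrogen at that place, such as piperidin-1-yl or 4-methylpiperazin-1-yl, or an open-chain dimethylamino group.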